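The source may report more compounds than this note shows. Statements on the series, on what has been measured and on what is new or still open speak of the compounds shown alone.

Compound 1 `CCCOC(=O)c1ccc(NC(=O)c2cccc(-c3cc(C(=O)Nc4ccncc4F)ccc3CN)c2)cc1`: in an assay on cells for inhibition of Rho-associated protein kinase 2 (Homo sapiens), read by radiometric assay and 33P incorporation, in the presence of a further agent that is not named here (on this read-out lower numbers stand for stronger inhibition and higher numbers for weaker inhibition), compound 1 gives < 1 nM, which is a limit of the assay and not a number.
Compound 2 `NCc1ccc(C(=O)Nc2ccncc2F)cc1-c1cccc(C(=O)Nc2ccc(CC(=O)O)cc2)c1`: compound 2 gives 1.8 nM.
Compound 3 `COC(=O)c1cccc(NC(=O)c2cccc(-c3cc(C(=O)Nc4ccncc4F)ccc3CN)c2)c1F`: compound 3 gives 1.2 nM.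

Among the measured compounds, compound 3 and compound 2 sit within the scatter of each other, a 1.5-fold lower number from compound 2 to compound 3 (0.18 log units; within the scatter), and compound 1 stands only at a limit, so no order between the three can be read from these numbers; compound 3 is simply the one with the smaller of the two measured values.

Compound 4 `CC(C)OC(=O)c1cccc(NC(=O)c2cccc(-c3cc(C(=O)Nc4ccncc4F)ccc3CN)c2)c1` differs from compound 3 at the amide-type nitrogen: 3-(isopropoxycarbonyl)phenyl in place of 2-fluoro-3-(methoxycarbonyl)phenyl on an amide-type nitrogen. Two measured steps change the group on that same nitrogen. Both stayed within the scatter: an at least 1.2-fold higher number from compound 1 to compound 3 (0.07 log units; that floor lies within the scatter) and a 1.5-fold lower number from compound 2 to compound 3 (0.18 log units; within the scatter), the first of these resting on a limit (the limit of < 1 nM in this assay, at which 1 of the 3 values shown sits). The step from compound 3 to compound 4 is therefore expected to be no larger than the scatter, with no direction to read, no change at the digits printed from compound 3 to compound 4 (within the scatter). Compound 4 is estimated at 1.2 nM, with a range from 0.5 nM to 3 nM.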

Compound 4, half-maximal inhibitory concentration: 7 nM
The estimate for compound 4 lay 5.8-fold (0.77 log units) below the measured number; measured number above the stated range.
By their numbers in this assay, from the lowest: compounds 3 and 2 (each within the scatter of the next); then compound 4. At a limit, below all of these: compound 1.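

In this assay, for the compounds shown here, the group on the amide-type nitrogen now makes a difference that can be read, whereas the earlier steps at this place stayed within the scatter. Replacing the 2-fluoro-3-(methoxycarbonyl)phenyl group gives a 5.8-fold higher number from compound 3 to compound 4 (0.77 log units; beyond the scatter), and the other two comparisons point the same way, with a 3.9-fold higher number from compound 2 to compound 4 (0.59 log units; beyond the scatter) and an at least 7.0-fold higher number from compound 1 to compound 4 (0.84 log units; beyond the scatter). The value of compound 1 is a limit of the assay and not a number, so its step gives only a floor: the limit of < 1 nM in this assay, at which 1 of the 4 values shown sits.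

The change from compound 3 to compound 4 removes the fluorine and replaces the methyl ester with an isopropyl ester in one move, so the compounds shown do not separate these two changes. A plain 3-(methoxycarbonyl)phenyl group, or a 3-(isopropoxycarbonyl)phenyl group that keeps the fluorine, would be needed to tell them apart.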